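The compounds below may be only part of what the source reports. "The series", "measured", "known", "first", "only" and "open" are said of these compounds alone.

Compound 1 `COc1cc(-c2ccnc3cc(-c4ccc(C)cc4)nn23)cc(OC)c1OC` gives 48 nM in a functional assay on HCT-116 cells (Homo sapiens) for inhibition, read by CCK-8 assay, with a stated time of 48 h; on this read-out higher numbers stand for weaker inhibition and lower numbers for stronger inhibition.
Compound 2 `COc1cc(-c2ccnc3cc(-c4cccc(C)c4)nn23)cc(OC)c1OC` gives 6150 nM in this assay.

Compound 1 holds the lowest number of the two measured compounds. Going by the values given here, the single measured step, a 130-fold higher number from compound 1 to compound 2 (2.11 log units; beyond the scatter), moves the methyl rather than replacing it, so no measured step shows the change that leads to compound 3 `COc1cc(-c2ccnc3cc(-c4ccc(C(F)(F)F)cc4)nn23)cc(OC)c1OC`: trifluoromethyl in place of methyl on an aromatic carbon. The step from compound 1 to compound 2 shows only that this part of the molecule is sensitive to change. For compound 3 the study therefore expects a modest step, a 2.1-fold higher number from compound 1 to compound 3 (0.32 log units; beyond the scatter), towards a somewhat higher number, estimated at 100 nM with a range of 20 nM to 600 nM.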

Compound 3, half-maximal inhibitory concentration: 1860 nM
Compound 3: middle estimate off by 19-fold (1.27 log units), on the low side; measured number above the stated range.
By their numbers in this assay, from the lowest: compound 1; then compound 3; then compound 2.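

In this assay, exchanging the methyl for trifluoromethyl in the same place gives a 39-fold higher number from compound 1 to compound 3 (1.59 log units; beyond the scatter), so this position responds to the group that sits there, not only to where the methyl stands. Moving the methyl still weighs more than this exchange, with a 3.3-fold lower number from compound 2 to compound 3 (0.52 log units; beyond the scatter) separating the two changes. Nothing available here accounts for either change. From the compounds shown here alone, whether a chlorine atom, a methoxy group or an amine in the same place would keep the low number of compound 1 stays open.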